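Dropping the chloro: compound 3 to compound 4

A few compounds are considered here, and "the series" means these few. Any claim that something is new, unique, unknown or untested is made for them only; others in the source may bear on it.

Measured so far:
- compound 1, `Cc1nnc(SCC(=O)N/N=c2/scc(-c3ccccc3)n2-c2ccccc2)s1`: 65.9%
- compound 2, `O=C(CSc1nnnn1-c1ccccc1)N/N=c1/scc(-c2ccc(Br)cc2)n1-c1ccccc1`: 47.9%
- compound 3, `O=C(CSc1nnnn1-c1ccccc1)N/N=c1/scc(-c2ccc(Cl)cc2)n1-c1ccccc1`: 62.3%

All three were tested in a functional assay on C6 cells (Rattus norvegicus) for cytotoxicity, read by MTT assay, with a stated time of 24 h, tested at 25 ug/mL; on this read-out higher numbers stand for a weaker effect at the one concentration tested and lower numbers for a stronger effect. On these numbers compound 3 stands second highest of three: compound 1 gives a number close to it, within the scatter, while compound 2 gives a number clearly lower, so compound 2 shows the stronger effect of the pair and compound 3 the weaker.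

Compound 4, `O=C(CSc1nnnn1-c1ccccc1)N/N=c1/scc(-c2ccccc2)n1-c1ccccc1`, differs from compound 3 in one place: hydrogen in place of chloro on an aromatic carbon. Going by the values given here, the only measured step at that place is a number 14.4 percentage points higher from compound 2 to compound 3 (beyond the scatter), which moved the number upward by a modest amount. Among the compounds with values here, no measured step removes a halogen altogether, so that step gives only a loose guide. Compound 1, which also carries a plain phenyl at the same place but a different sulfur-linked heteroaryl, sits within the scatter of compound 3 in this assay.

Taken together, a step of a number 3.7 percentage points higher from compound 3 to compound 4 (within the scatter) is expected, in other words nothing clearly beyond the scatter. Compound 4 is therefore estimated at 66%, with a range from 52% to 80%.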

Compound 4, a percentage reported as activity, at one concentration (the size of the read-out at that concentration, not a potency): 42.5%
The estimate for compound 4 lay 23.5 percentage points above the measured number, outside the stated range (below it).
By their numbers in this assay, from the lowest: compounds 4 and 2 (each within the scatter of the next); then compounds 3 and 1 (each within the scatter of the next).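

Removing the chloro, the change from 4-chlorophenyl to phenyl, gives a number 19.8 percentage points lower from compound 3 to compound 4 (beyond the scatter) in this assay, so the compound with hydrogen at this place has the clearly stronger effect on this read-out. Hydrogen in place of bromo gives a number 5.4 percentage points lower from compound 2 to compound 4 (within the scatter) and therefore no readable change, which, set beside a number 14.4 percentage points higher from compound 2 to compound 3 (beyond the scatter) for the swap of bromo to chloro, leaves chloro as the one group of the three that stands apart, rather than halogen against no halogen. Going by these compounds alone, with a plain phenyl held constant, the new pair also isolates the group on the sulfur for the first time: 1-phenyl-1H-tetrazol-5-yl in place of 5-methyl-1,3,4-thiadiazol-2-yl gives a number 23.4 percentage points lower from compound 1 to compound 4 (beyond the scatter) and so a stronger effect in the same read-out.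

Still open, on these data alone, is whether a fluoro, a methyl or an amine at this place would fall with chloro or with hydrogen and bromo, and whether the swap on the sulfur would give a similar step with chloro on the phenyl. No measurement at hand explains any of these steps.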